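The compounds below may be only part of what the source reports. "The series", "measured", "known", "first", "only" and "open" are said of these compounds alone.

Compound 2 `C=C(C)C(=O)Nc1cccc(-c2nc3ccccc3s2)c1` is measured in an ADME assay on HEK293 cells (Homo sapiens) for inhibition, with a stated time of 72 h; a lower number here means that less compound is needed, a higher number that more compound is needed for the effect. There compound 2 reaches only a limit, > 25000 nM. Its neighbour compound 1 `C=CC(=O)Nc1cccc(-c2nc3ccccc3s2)c1` likewise gives only a limit in this assay, > 25000 nM. Compound 3 `CC(Cl)C(=O)Nc1cccc(-c2nc3ccccc3s2)c1` also stops at a limit in this assay, > 25000 nM. Because all three sit at the limit of > 25000 nM in this assay, at which 3 of the 3 values shown sit, the steps a step that the two limits leave unreadable from compound 1 to compound 2, a step that the two limits leave unreadable from compound 1 to compound 3 and a step that the two limits leave unreadable from compound 2 to compound 3 cannot be sized. The change to compound 4 `O=C(Nc1cccc(-c2nc3ccccc3s2)c1)c1cccnc1Cl` is 2-chloropyridin-3-yl in place of 1-methylethenyl on a carbonyl carbon. Within the data shown here, no measured step bears readably on it, so the account expects no step beyond the scatter, a step that the limit leaves unreadable from compound 2 to compound 4, in this assay. Compound 4 is therefore estimated at 30000 nM, within 8000 nM to 100000 nM, most likely again reported as a limit.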

Compound 4, half-maximal effective concentration: > 25000 nM
Compound 4 ended at the assay's limit; the forecaster's own chance of this, stated with the estimate: 70%; the middle value does not contradict the limit.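

No step from compound 1, compound 2 or compound 3 to compound 4 can be read, as all four stop at the same limit: the limit of > 25000 nM in this assay, at which 4 of the 4 values shown sit.

The compounds shown leave open how far each lies past that limit, and whether the groups on the carbonyl carbon differ at all.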